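The source may hold more compounds than are shown below. What is called first, only, known or untested is meant among the compounds shown, and "the series" means these compounds.

- Compound 1 `OC[C@H]1O[C@@H](n2cnc3c(NCc4ccc(Br)cc4)ncnc32)[C@H](O)[C@@H]1O`: 68200 nM
- Compound 2 `OC[C@H]1O[C@@H](n2cnc3c(NCc4ccc(F)c(F)c4F)ncnc32)[C@H](O)[C@@H]1O`: > 166000 nM
- Compound 3 `OC[C@H]1O[C@@H](n2cnc3c(NCc4c(F)ccc(F)c4F)ncnc32)[C@H](O)[C@@H]1O`: > 166000 nM
- Compound 4 `OC[C@H]1O[C@@H](n2cnc3c(NCc4ccc(F)c(Cl)c4)ncnc32)[C@H](O)[C@@H]1O`: not yet measured

In a functional assay on K562 cells (Homo sapiens) for antiproliferative activity, with a stated time of 72 h (on this read-out higher numbers stand for weaker inhibition and lower numbers for stronger inhibition), compound 3 gives > 166000 nM, which is a limit and not a number. Compound 3 thus stands at the limit of > 166000 nM in this assay, at which 2 of the 3 values shown sit. Moving to compound 4 brings this change: 3-chloro-4-fluorophenyl in place of 2,3,6-trifluorophenyl on a saturated chain carbon bound to a nitrogen on an aromatic ring. The 2,3,6-trifluorophenyl leaves and 3-chloro-4-fluorophenyl enters. For the measured compounds named here, two measured steps bear on this: an at least 2.4-fold higher number from compound 1 to compound 3 (0.38 log units; beyond the scatter) and an at least 2.4-fold higher number from compound 1 to compound 2 (0.38 log units; beyond the scatter). Going by the values given here, both start from compound 1, the only compound with a true number, 68200 nM. The step that the two limits leave unreadable from compound 2 to compound 3 adds nothing. Removing the trifluorophenyl group should therefore partly reverse that rise, so a modest move to a lower number is expected: an at least 1.8-fold lower number from compound 3 to compound 4 (0.26 log units; that floor lies within the scatter). For compound 4 the estimated value is 90000 nM, with an expected range of 40000 nM to 170000 nM.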

Compound 4, half-maximal inhibitory concentration: 5500 nM
The estimate for compound 4 lay 16-fold (1.21 log units) above the measured number; measured number outside the range, below it.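

In this assay, 3-chloro-4-fluorophenyl gives an at least 30-fold lower number from compound 3 to compound 4 (1.47 log units; beyond the scatter) and an at least 30-fold lower number from compound 2 to compound 4 (1.47 log units; beyond the scatter). For the compounds shown here, compound 2 and compound 3 hold only limits, not numbers: the limit of > 166000 nM in this assay, at which 2 of the 4 values shown sit. Against compound 1, the only earlier true number, the same group gives a 12-fold lower number from compound 1 to compound 4 (1.09 log units; beyond the scatter), so a change at this place can strengthen inhibition as well as weaken it.

Going by these compounds, whether the chlorine or the fluorine of compound 4 matters more remains open, and a 3-chlorophenyl or a 4-fluorophenyl group would separate them. On these data alone, how an amine or a longer chain would behave at this place is also open.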